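Amino for acetyl on the pendant aryl: expected growth inhibition

This account rests on a few compounds, and the source may have more. Where it says the series, first, only, none or still open, it means among the compounds named here.

Measured so far:
compound 1, `COC(=O)c1sc2cc(-c3ccc(F)nc3)cnc2c1N`: "not determined" (no result reported) in a functional assay on A-375 cells (Homo sapiens) for inhibition, read by sulforhodamine B assay, with a stated time of 48 h; on this read-out higher numbers stand for weaker inhibition of growth and lower numbers for stronger inhibition of growth
compound 2, `COC(=O)c1sc2cc(-c3ccc(C(C)=O)cc3)cnc2c1N`: > 150000 nM in this assay

Compound 2 sits at the limit of this assay, (the limit of > 150000 nM in this assay, at which 1 of the 2 values shown sits), so the value is a limit and not a number. Compound 1 has no result reported. Compound 3, `COC(=O)c1sc2cc(-c3ccc(N)cc3)cnc2c1N`, differs from compound 2 by amino in place of acetyl on an aromatic carbon. Among the measured compounds shown here, no measured step between two compounds exists here, so the expected step of an at least 1.2-fold lower number from compound 2 to compound 3 (0.09 log units; that floor lies within the scatter) is none beyond the scatter. Compound 3 is therefore estimated at 120000 nM, with a range from 20000 nM to 300000 nM, and a limit rather than a number is the likelier outcome.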

Compound 3, concentration for 50% growth inhibition: 80800 nM
Beside the measured number, compound 3's estimate is 1.5-fold (0.17 log units) above it; the range from low to high includes it.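

In this assay, amino in place of acetyl on an aromatic carbon, para to a large group, gives the first single number shown for this position, with an at least 1.8-fold lower number from compound 2 to compound 3 (0.26 log units; that floor lies within the scatter). The size of this step remains unresolved, as the value of compound 2 is a limit and not a number: the limit of > 150000 nM in this assay, at which 1 of the 3 values shown sits.

The change at this position can therefore bring a compound onto the measurable range, although the printed floor does not establish a difference beyond the scatter. Still open, as far as these compounds go, is how a hydroxyl, methylamino or acetamide group on the same carbon would read against amino.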